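Methyl ester to methylamide on a shared benzimidazole-free core

A few compounds are considered here, and "the series" means these few. Any claim that something is new, unique, unknown or untested is made for them only; others in the source may bear on it.

Measured so far:
compound 1, `COc1ccc(Nc2nc3cc(C(=O)Nc4ccccc4OC)ccc3n2Cc2ccccc2C(F)(F)F)cc1`, > 50000 nM in an assay on isolated protein for inhibition of kinesin heavy chain isoform 5A (Homo sapiens); a lower number here means a stronger inhibitor, a higher number a weaker inhibitor
compound 2, `CS(=O)(=O)c1ccc(Nc2nc3cc(C(=O)O)ccc3n2Cc2ccccc2C(F)(F)F)cc1`, > 50000 nM in this assay
compound 3, `COC(=O)c1ccc2c(c1)nc(Nc1ccc(S(N)(=O)=O)cc1)n2Cc1ccccc1C(F)(F)F`, > 50000 nM in this assay

Compound 3 stands at the limit of > 50000 nM in this assay, at which 3 of the 3 values shown sit: its result is a limit of the assay and not a number. The same holds for compound 1, whose value in this assay is a limit. The same holds for compound 2, whose value in this assay is also a limit. No step between two measured compounds can therefore be sized, and nothing shown distinguishes one of the three from another.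

Compound 4, `CNC(=O)c1ccc2c(c1)nc(Nc1ccc(S(N)(=O)=O)cc1)n2Cc1ccccc1C(F)(F)F`, differs from compound 3 in one place: methylamino in place of methoxy on a carbonyl carbon. Within the data shown here, since every value in this assay sits at the limit, no direction can be read from the data for this change; an expectation of no step beyond the scatter is the only one the numbers support, and the step is expected as a step that the limit leaves unreadable from compound 3 to compound 4. Compound 4 is accordingly expected to give about 60000 nM, within 15000 nM to 200000 nM, and the measurement is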

Compound 4, half-maximal inhibitory concentration: > 50000 nM
Compound 4 ended at the assay's limit; the forecaster's own chance of this, stated with the estimate: 85%; the middle value is on the limit's open side.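

No step can be read from compound 3 to compound 4, whose results in this assay are both limits of the assay: the limit of > 50000 nM in this assay, at which 4 of the 4 values shown sit.

The compounds shown leave open whether methoxy and methylamino on a carbonyl carbon differ at all, and what any compound on the shared core would give as an actual number.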